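A few compounds are considered here, and "the series" means these few. Any claim that something is new, unique, unknown or untested is made for them only; others in the source may bear on it.

Measured so far in a functional assay on MCF7 cells (Homo sapiens) for antiproliferative activity, read by MTT assay, with a stated time of 72 h; on this read-out higher numbers stand for weaker inhibition and lower numbers for stronger inhibition:
compound 1, `O=C(COc1ccc(C(=O)/C=C/c2ccccc2Cl)cc1)N[C@H]1CCOC1=O`: 17400 nM
compound 2, `O=C(COc1ccc(C(=O)/C=C/c2ccc(F)cc2)cc1)N[C@H]1CCOC1=O`: a limit only, > 64000 nM
compound 3, `CC(C)(C)c1ccc(/C=C/C(=O)c2ccc(OCC(=O)N[C@H]3CCOC3=O)cc2)cc1`: 16400 nM

Compound 3 and compound 1 sit within the scatter of each other in this assay, as the step of a 1.1-fold lower number from compound 1 to compound 3 (0.03 log units; within the scatter) shows, so neither can be called the stronger of the two. Compound 2 stands at the limit of > 64000 nM in this assay, at which 1 of the 3 values shown sits. The steps of an at least 3.6-fold higher number from compound 1 to compound 2 (0.56 log units; beyond the scatter) and an at least 3.9-fold lower number from compound 2 to compound 3 (0.59 log units; beyond the scatter) are both beyond the scatter and both point the same way, away from the fluoro-bearing compound 2.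

Compound 4, `CC(C)c1ccc(/C=C/C(=O)c2ccc(OCC(=O)N[C@H]3CCOC3=O)cc2)cc1`, differs from compound 3 by hydrogen in place of methyl on a saturated chain carbon bound to an aromatic carbon and two saturated chain carbons. Among the measured compounds shown here, no measured step removes a single methyl from this group. For the measured compounds named here, the only steps that touch this position are an at least 3.9-fold lower number from compound 2 to compound 3 (0.59 log units; beyond the scatter), beyond the scatter, where the whole substituent changed from fluoro, and a 1.1-fold lower number from compound 1 to compound 3 (0.03 log units; within the scatter), within the scatter, where a 2-chlorophenyl became a 4-(tert-butyl)phenyl. Trimming tert-butyl to isopropyl is a smaller change than either, so the expected step of a 1.2-fold higher number from compound 3 to compound 4 (0.09 log units; within the scatter) in this assay is within the scatter, with no direction claimed. Compound 4 is therefore expected to give about 20000 nM in this assay, with a range from 8000 nM to 50000 nM.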

Compound 4, half-maximal inhibitory concentration: 23400 nM
Estimate against measurement, compound 4: 1.2-fold (0.07 log units) below; the measured number falls inside the stated range.
By their numbers in this assay, from the lowest: compounds 3, 1 and 4 (each within the scatter of the next). At a limit, above all of these: compound 2.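

In this assay, among the compounds shown here, the first step that touches only this position, trimming tert-butyl to isopropyl, gives a 1.4-fold higher number from compound 3 to compound 4 (0.15 log units; within the scatter), and the comparison with the 2-chlorophenyl compound gives a 1.3-fold higher number from compound 1 to compound 4 (0.13 log units; within the scatter), so compound 1, compound 3 and compound 4 cannot be placed in any order. The separation from the fluoro compound persists with the smaller alkyl group, as an at least 2.7-fold lower number from compound 2 to compound 4 (0.43 log units; beyond the scatter) shows, so the tert-butyl group as a whole is not required for that separation in this series. The value for compound 2 is a limit only, so the full size of that separation cannot be read: the limit of > 64000 nM in this assay, at which 1 of the 4 values shown sits.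

The compounds shown do not tell whether a methyl or ethyl group on the same aromatic carbon would stay with compound 3 and compound 4 or fall with compound 2. They also leave open how an amine, a carboxylic acid or a longer alkyl chain at that carbon would read out, and whether any such group would give a step beyond the scatter from compound 3.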